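Benzimidazole series: propyl to (pyridin-2-yl)methyl on the ring nitrogen

A few compounds are considered here, and "the series" means these few. Any claim that something is new, unique, unknown or untested is made for them only; others in the source may bear on it.

Measured so far:
compound 1 `Cc1cccc(CSc2nc3cc(NC(=O)C4CC4)ccc3n2C(C)C)c1` — > 10000 nM
compound 2 `CCCn1c(SCc2cc([N+](=O)[O-])ccc2OC)nc2cc(NC(=O)NC(C)(C)C)ccc21` — 120 nM

Within the data shown here, in an assay on isolated protein for inhibition of Gonadotropin-releasing hormone receptor (Rattus norvegicus) (on this read-out lower numbers stand for stronger inhibition and higher numbers for weaker inhibition), compound 2 gives 120 nM, the only number recorded. Compound 1 `Cc1cccc(CSc2nc3cc(NC(=O)C4CC4)ccc3n2C(C)C)c1` reaches only the assay limit of > 10000 nM, a limit and not a number; this is the point at which the limit of > 10000 nM in this assay, at which 1 of the 2 values shown sits, sits. Among the measured compounds shown here, compound 2 therefore stands alone as the sole quantified reference, with no measured step to compare against.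

Compound 3 `COc1ccc([N+](=O)[O-])cc1CSc1nc2cc(NC(=O)NC(C)(C)C)ccc2n1Cc1ccccn1` is not yet measured. It differs from compound 2 by pyridin-2-yl in place of ethyl on a saturated chain carbon bound to an aromatic nitrogen. With no measured step of this kind in the series, the step from compound 2 to compound 3 is expected to be modest, a 1.5-fold lower number from compound 2 to compound 3 (0.18 log units; within the scatter), possibly within the scatter or a slight gain. Compound 3 is estimated at 80 nM in this assay, within 25 nM to 300 nM.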

Compound 3, half-maximal inhibitory concentration: 670 nM
Beside the measured number, compound 3's estimate is 8.4-fold (0.92 log units) below it; measured number above the stated range.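

In this assay, the ring nitrogen now has its first readable step, for propyl to (pyridin-2-yl)methyl: a 5.6-fold higher number from compound 2 to compound 3 (0.75 log units; beyond the scatter). This substituent therefore affects the read-out, and the added pyridin-2-yl ring weakens inhibition beyond the scatter in this one pair, although compound 3 still gives a number, 670 nM, and not a limit. Nothing in the data shown explains this loss.

Going by these compounds, it remains open whether the loss follows from the pyridine nitrogen or from the added ring itself, a question that a benzyl group at the same place would address. On these data alone, a butyl chain there would show how the read-out responds to simple extension of the propyl group, and the step's size with other groups on the shared core also remains unknown.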